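The compounds below may be only part of what the source reports. "The series", "measured", "known", "first", "only" and "open" are said of these compounds alone.

Two compounds carry numbers in an assay on CHO cells for displacement of a labelled ligand from prostaglandin E2 receptor EP3 subtype (Homo sapiens), read by radioligand binding; on this read-out lower numbers stand for stronger inhibition and higher numbers for weaker inhibition. Compound 1 `CC(C)C(c1ncco1)c1ccc(-c2ccc3cccc(F)c3c2)[nH]c1=O` gives 24 nM in this assay, and compound 2 `CCn1ncc2c(C)cc(-c3ccc([C@@]4(C)CCNC4=O)c(=O)[nH]3)cc21` gives 5 nM. Among the measured compounds shown here, compound 1 thus stands at the higher of the two numbers; its gap to compound 2 lies beyond the usual scatter of repeated runs, but the two differ in several places at once, so no single-point step can be drawn between them.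

Compound 3 `CC(C)C(c1nnc[nH]1)c1ccc(-c2ccc3cccc(F)c3c2)[nH]c1=O` awaits measurement. It differs from compound 1 in one place: 4H-1,2,4-triazol-3-yl in place of 1,3-oxazol-2-yl on a saturated chain carbon bound to an aromatic carbon and a saturated chain carbon. For the measured compounds named here, the leaving and entering groups are both five-membered aromatic rings, and no measured pair in this set shows the effect of such a swap, so the expectation rests on the exchange alone. The step from compound 1 to compound 3 in this assay is estimated at a 1.5-fold higher number from compound 1 to compound 3 (0.16 log units; within the scatter), nothing clearly beyond the scatter, with room for a modest loss. Compound 3 is expected to give 35 nM in this assay, within a range from 9 nM to 140 nM.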

Compound 3, inhibition constant: 12 nM
Compound 3: the middle estimate sits 2.9-fold (0.46 log units) above what was measured; measured number inside the range.
By their numbers in this assay, from the lowest: compound 2; then compounds 3 and 1 (each within the scatter of the next).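

Within the scatter, the step of a 2.0-fold lower number from compound 1 to compound 3 (0.30 log units; within the scatter) gives no sign that this assay separates 1,3-oxazol-2-yl from 4H-1,2,4-triazol-3-yl on this saturated chain carbon. This first single-point comparison in the series therefore shows that one five-membered aromatic ring can replace the other here without a change beyond the scatter, even though the entering ring brings a hydrogen-bond donor that the leaving ring lacks. No supporting evidence bears on this result.

Open, from the compounds shown here alone, is whether this place needs an aromatic ring at all, or whether a carboxylic acid or a primary amine on the same saturated chain carbon would stay within the same range. Also open, going by these compounds, is whether the result would hold with a longer chain in place of the 2-methylpropyl part.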